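The source may report more compounds than this note shows. Statements on the series, on what has been measured and on what is new or still open speak of the compounds shown alone.

Measured so far:
Compound 1, `Cn1ccc2c(Oc3ccc(NC(=O)c4cc5cccnc5n(-c5ccc(F)cc5)c4=O)cc3F)ncnc21` — 11900 nM
Compound 2, `Cn1ccc2c(Oc3ccc(NC(=O)c4cc5cccnc5n(-c5ccc(C(F)(F)F)c(Cl)c5)c4=O)cc3F)ncnc21` — "not active" (no number reported)

Among the compounds with values here, in a functional assay on MCF7 cells (Homo sapiens) for cytotoxicity, read by MTT assay, with a stated time of 72 h (a lower number here means a stronger inhibitor, a higher number a weaker inhibitor), compound 1 gives 11900 nM and is the only compound of the pair for which a number is known; compound 2 is reported as "not active" (no number reported) without a number, so no step between the two measured compounds can be stated. Compound 3, `O=C(Nc1ccc(Oc2ncnc3[nH]ccc23)c(F)c1)c1cc2cccnc2n(-c2ccc(F)cc2)c1=O`, has not yet been measured in this assay. It differs from compound 1 in one place: hydrogen in place of methyl on an aromatic nitrogen. Within the data shown here, whether the loss of a methyl on an aromatic nitrogen at that place moves the cytotoxicity is not told by anything measured here, and with only a single number in hand no trend can be read. The step expected in this assay is therefore small, a 1.2-fold lower number from compound 1 to compound 3 (0.08 log units; within the scatter), with no clear direction beyond the scatter. Compound 3 is estimated at 10000 nM, within a range from 3000 nM to 40000 nM.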

Compound 3, half-maximal inhibitory concentration: 9230 nM
The estimate for compound 3 lay 1.1-fold (0.03 log units) above the measured number; low and high end bracket the measured number.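

Between the two compounds that differ in one place, the change from methyl to hydrogen on the aromatic nitrogen gives, in this assay, a 1.3-fold lower number from compound 1 to compound 3 (0.11 log units; within the scatter). Methyl and hydrogen at this place therefore cannot be told apart in this read-out, and the methyl of compound 1 is shown not to be required for a measurable number. Nothing available explains this result.

The compounds shown leave open whether a larger group on the same nitrogen, such as an ethyl group or a longer chain ending in an amine, would give a different number. Steps involving compound 2 cannot be read, as it has no number, so the shown compounds also leave open how its substituents act.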